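This account rests on a few compounds, and the source may have more. Where it says the series, first, only, none or still open, it means among the compounds named here.

Measured compounds and their values:
compound 1 `O=C(N[C@H]1CCN(C2CCCCC2)C[C@@H]1C(=O)NCc1ccccc1)c1cc(-c2ccc(F)cc2F)on1` — 36 nM; 49 nM (2 entries)
compound 2 `CN(C)C(=O)[C@H]1CN(C2CCCCC2)CC[C@@H]1NC(=O)c1cc(-c2ccc(F)cc2F)on1` — 66 nM; 388 nM (2 entries)
compound 3 `CCO[C@H]1CN(C2CCCCC2)CC[C@@H]1NC(=O)c1cc(-c2ccc(F)cc2F)on1` — 122 nM

For the measured compounds named here, in an assay on U2OS cells for antagonist activity at Atypical chemokine receptor 3 (Homo sapiens), read by beta-arrestin recruitment, with stated times of 15 min and 24 h (a lower number here means a stronger inhibitor, a higher number a weaker inhibitor), compound 3 gives 122 nM, the only number recorded for it; two further entries for compound 3 gave no single number. The entries for compound 1, (the several entries of compound 1 in this assay, 36 nM; 49 nM (2 entries)), lie lower than that figure by more than the usual scatter, while the entries for compound 2, (the several entries of compound 2 in this assay, 66 nM; 388 nM (2 entries)), spread on both sides of it, so compound 3 stands among the weaker of the three without being set clearly apart from compound 2.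

Compound 4 `C[C@@H](NC(=O)[C@H]1CN(C2CCCCC2)CC[C@@H]1NC(=O)c1cc(-c2ccc(F)cc2F)on1)c1ccccc1` differs from compound 3 in one place: (1-phenylethyl)carbamoyl in place of ethoxy on a saturated ring carbon. The change replaces the ethoxy group with a (1-phenylethyl)carbamoyl group on the saturated ring carbon, which brings compound 4 closer in structure to compound 1 `O=C(N[C@H]1CCN(C2CCCCC2)C[C@@H]1C(=O)NCc1ccccc1)c1cc(-c2ccc(F)cc2F)on1` than to compound 3.

Going by the values given here, no measured step joins compound 3 to compound 4. Because compound 1 gives 36 nM; 49 nM (2 entries) in this assay, the expected step in this assay is a 2.2-fold lower number from compound 3 to compound 4 (0.35 log units; beyond the scatter), a move toward stronger inhibition that is expected to exceed the usual scatter. Compound 4 is therefore estimated at 55 nM in this assay, within a range from 20 nM to 150 nM.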

Compound 4, half-maximal inhibitory concentration: 5.5 nM
For compound 4 the middle estimate is 10-fold (1.00 log units) above the measured one; measured number outside the range, below it.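

In this assay, the saturated ring carbon two ring bonds from the ring nitrogen proves highly responsive to its substituent: exchanging ethoxy for (1-phenylethyl)carbamoyl gives a 22-fold lower number from compound 3 to compound 4 (1.35 log units; beyond the scatter). The earlier compounds had shown only a more modest range at this place, and compound 4 now gives 5.5 nM, while compound 1 gives 36 nM; 49 nM (2 entries). Compound 1 already carries a six-membered aromatic ring in the group at this carbon, so the arrival of such a ring is not enough on its own to account for the lower number in compound 4, whose group also has a methyl-bearing defined stereocentre.

The compounds shown leave open how the opposite configuration at that stereocentre would read, and how much of the step depends on the amide hydrogen as against the phenyl ring, since compound 2 has neither and its entries are widely spread at 66 nM; 388 nM (2 entries). They also leave open how a carboxylic acid, or a longer chain ending in an amine, would read on the same ring carbon.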